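A few compounds are considered here, and "the series" means these few. Any claim that something is new, unique, unknown or untested is made for them only; others in the source may bear on it.

Measured so far in an ADME assay on MT4 cells (Homo sapiens) for cytotoxicity, read by MTT assay, with a stated time of 5 days; on this read-out lower numbers stand for higher toxicity in this test and higher numbers for lower toxicity in this test:
- compound 1, `N#Cc1ccc(Nc2nccc(OCc3cccc(Cl)c3)n2)cc1`: 153000 nM
- compound 2, `N#Cc1ccc(Nc2nccc(OCc3ccccc3Br)n2)cc1`: 130000 nM

Compound 1 holds the higher of the two numbers shown, but only by a margin the test cannot resolve: the one measured step, a 1.2-fold lower number from compound 1 to compound 2 (0.07 log units; within the scatter), lies within the scatter, so compounds 1 and 2 are to be read as giving the same outcome in this assay.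

Compound 3, `COc1ccccc1COc1ccnc(Nc2ccc(C#N)cc2)n1`, is still to be measured. Against compound 1 its structure changes in one place: 2-methoxyphenyl in place of 3-chlorophenyl on a saturated chain carbon bound to an oxygen on an aromatic ring

Among the measured compounds shown here, the only measured step at the same place, from compound 1 to compound 2, replaced 3-chlorophenyl with 2-bromophenyl and gave a 1.2-fold lower number from compound 1 to compound 2 (0.07 log units; within the scatter), nothing beyond the scatter. For the measured compounds named here, no measured pair in this set shows what a 2-methoxyphenyl group does at this place, so the expectation rests on that one flat step alone. The expected step is therefore small and of no clear direction, a 1.1-fold lower number from compound 1 to compound 3 (0.04 log units; within the scatter), with the number kept close to compound 1. Compound 3 is estimated at 140000 nM in this assay, with a range of 70000 nM to 280000 nM.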

Compound 3, half-maximal cytotoxic concentration: 8900 nM
Compound 3: middle estimate off by 16-fold (1.20 log units), on the high side; the whole stated range lies above it.
By their numbers in this assay, from the lowest: compound 3; then compounds 2 and 1 (each within the scatter of the next).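

In this assay, among the compounds shown here, the group on a saturated chain carbon bound to an oxygen on an aromatic ring proves able to move the read-out strongly, which the single flat step among the earlier compounds gave no sign of: 2-methoxyphenyl in place of 3-chlorophenyl gives (a 17-fold lower number from compound 1 to compound 3 (1.24 log units; beyond the scatter)), and methoxy in place of bromo on an aromatic carbon gives (a 15-fold lower number from compound 2 to compound 3 (1.16 log units; beyond the scatter)). The second step is the narrower comparison, since the two compounds differ only in that one substituent, and the lower number stands for higher toxicity in this test, so in this small set the methoxy-bearing compound 3 is the one that stands apart. Nothing at hand accounts for the size of this step.

On these data alone, it remains open whether the low number is specific to methoxy or would also appear with an ethoxy, a hydroxyl or an amine on the same ring. Also open, as far as these compounds go, is whether a methoxy group would have the same effect on compounds with a different core.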